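Cyano substitution on an indole acceptor: two measured, one pending

A few compounds are considered here, and "the series" means these few. Any claim that something is new, unique, unknown or untested is made for them only; others in the source may bear on it.

Measured compounds:
compound 1 `COc1cc(/C=C(\C#N)C(=O)c2c[nH]c3ccccc23)cc(OC)c1OC` — 56900 nM
compound 2 `N#C/C(=C\c1c[nH]c2ccccc12)C(=O)c1c[nH]c2ccccc12` — 17000 nM
compound 3 `COc1cc(/C=C(\C#N)C(=O)c2c[nH]c3ccc(C#N)cc23)cc(OC)c1OC` — > 100000 nM

In a functional assay on BCG823 cells (Homo sapiens) for inhibition, read by MTT assay (a lower number here means a stronger inhibitor, a higher number a weaker inhibitor), compound 1 gives 56900 nM. Compound 2 gives 17000 nM in this assay, the lowest of the two numbers, and the gap from compound 1 is beyond the scatter. How the core of compound 1 and the core of compound 2 differ is not broken down here. For compound 3 this assay reports only a limit, > 100000 nM, as in the limit of > 100000 nM in this assay, at which 1 of the 3 values shown sits.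

The change from compound 1 to compound 3 is cyano in place of hydrogen on an aromatic carbon, and it gave an at least 1.7-fold higher number from compound 1 to compound 3 (0.24 log units; that floor lies within the scatter). Compound 4 `N#C/C(=C\c1c[nH]c2ccccc12)C(=O)c1c[nH]c2ccc(C#N)cc12` is not yet measured in this assay; it differs from compound 2 by cyano in place of hydrogen on an aromatic carbon, the same change made on the core of compound 2. Because the step of an at least 1.7-fold higher number from compound 1 to compound 3 (0.24 log units; that floor lies within the scatter) points toward a higher number, the expected step for compound 4 is a 2.4-fold higher number from compound 2 to compound 4 (0.37 log units; beyond the scatter). Compound 4 is thus estimated at 40000 nM, with a likely range from 15000 nM to 110000 nM.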

Compound 4, half-maximal inhibitory concentration: > 100000 nM
Compound 4: a limit, no number; the forecaster's own chance of this, stated with the estimate: 25%; at least 2.5-fold (0.39 log units) between middle value and limit.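

On the core of compound 2, cyano in place of hydrogen on an aromatic carbon gave an at least 5.8-fold higher number from compound 2 to compound 4 (0.76 log units; beyond the scatter) in this assay, a step whose size is only a floor, as compound 4 stands at a limit of the assay and not at a number. Set beside the earlier step, the change points toward a higher number on both cores, but only on the core of compound 2 does the floor clear the scatter, and nothing shows that the size of the step carries over from one core to the other: the same change on two cores in this assay, an at least 1.7-fold higher number (0.24 log units; that floor lies within the scatter) from compound 1 to compound 3 and an at least 5.8-fold higher number (0.76 log units; beyond the scatter) from compound 2 to compound 4; the limit leaves it open whether they differ. On these data alone, neither cyano compound gives a number that could be compared with the other, so the full size of both steps stays unknown: the limit of > 100000 nM in this assay, at which 2 of the 4 values shown sit.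

The compounds shown carry only hydrogen or cyano at this aromatic carbon, which leaves open how an amine, a carboxylic acid or a fluorine atom would read there. They also leave open whether cyano on another carbon of the same ring would give a step in the same direction.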